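Aryl variation on the aromatic nitrogen of the spiro series

The source may hold more compounds than are shown below. What is called first, only, known or untested is meant among the compounds shown, and "the series" means these compounds.

Compound 3 `N#CC1=C(N)Oc2c(c3nc4ccccc4nc3c3ccccc23)C12C(=O)N(Cc1cnnn1-c1ccc(F)c(Cl)c1)c1ccccc12` carries a 3-chloro-4-fluorophenyl on an aromatic nitrogen. In a functional assay on MCF7 cells (Homo sapiens) for antiproliferative activity, read by MTT assay, with a stated time of 48 h (on this read-out lower numbers stand for stronger inhibition and higher numbers for weaker inhibition), compound 3 gives only the limit > 50000 nM and no number. Compound 1 `N#CC1=C(N)Oc2c(c3nc4ccccc4nc3c3ccccc23)C12C(=O)N(Cc1cnnn1-c1cccc(Br)c1)c1ccccc12`, with a 3-bromophenyl in that place, likewise gives only the limit > 50000 nM in this assay. Within the data shown here, compound 2 `N#CC1=C(N)Oc2c(c3nc4ccccc4nc3c3ccccc23)C12C(=O)N(Cc1cnnn1-c1cccc(S(N)(=O)=O)c1)c1ccccc12`, with a 3-sulfamoylphenyl, gives 42500 nM in this assay, the one value that is a number. The measured steps are an at least 1.1-fold lower number from compound 1 to compound 2 (0.07 log units; that floor lies within the scatter), an at least 1.1-fold higher number from compound 2 to compound 3 (0.07 log units; that floor lies within the scatter) and a step that the two limits leave unreadable from compound 1 to compound 3; the limit of > 50000 nM in this assay, at which 2 of the 3 values shown sit, leaves every one of them at or within the scatter. Compound 4 `N#CC1=C(N)Oc2c(c3nc4ccccc4nc3c3ccccc23)C12C(=O)N(Cc1cnnn1-c1cc(Cl)ccc1Cl)c1ccccc12` is the next variation on the same position: 2,5-dichlorophenyl in place of 3-chloro-4-fluorophenyl on an aromatic nitrogen. Among the measured compounds shown here, none of the measured steps moved the number readably, and the change once more exchanges only the substituents on the phenyl, so no step beyond the scatter is expected in this assay: a step that the limit leaves unreadable from compound 3 to compound 4. The expected value for compound 4 is 60000 nM, within 30000 nM to 150000 nM, most likely reported again as a limit.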

Compound 4, half-maximal inhibitory concentration: > 50000 nM
Compound 4 ended at the assay's limit; the forecaster's own chance of this, stated with the estimate: 75%; the middle value does not contradict the limit.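

In this assay compound 4 gives > 50000 nM, which is a limit and not a number. A 2,5-dichlorophenyl on the aromatic nitrogen thus joins the 3-bromophenyl and the 3-chloro-4-fluorophenyl among the groups without a numerical value, and two chlorines on the phenyl give no readable change. The only step with a stated size is an at least 1.1-fold higher number from compound 2 to compound 4 (0.07 log units; that floor lies within the scatter), while the other two new steps, both between limits, cannot be read, so the aryl changes shown separate no compound beyond the scatter: the limit of > 50000 nM in this assay, at which 3 of the 4 values shown sit.

Still open, from the compounds shown here alone, is whether a carboxylic acid or an amine on the phenyl would give a number clearly apart from that of compound 2 in this assay. Also open, going by these compounds, is whether a longer chain between the aromatic nitrogen and the phenyl would do so.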